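From 4-methoxyphenyl to 3-chlorophenyl near an assay limit

The source may hold more compounds than are shown below. What is called first, only, known or untested is meant among the compounds shown, and "the series" means these compounds.

Measured in a functional assay on DU-145 cells (Homo sapiens) for antiproliferative activity, read by MTT assay, with a stated time of 48 h; a lower number here means a stronger inhibitor, a higher number a weaker inhibitor:
compound 1 `C/C(=C\CC/C(C)=C/CC[C@@H]1[C@@]2(C)CCC(=O)C(C)(C)[C@H]2CC[C@@]1(C)O)CC/C=C(\C)C(=O)OCc1cn(-c2ccccc2Br)nn1`: > 150000 nM, a limit
compound 2 `C/C(=C\CC/C(C)=C/CC[C@@H]1[C@@]2(C)CCC(=O)C(C)(C)[C@H]2CC[C@@]1(C)O)CC/C=C(\C)C(=O)OCc1cn(-c2ccc(F)c(Cl)c2)nn1`: > 150000 nM, a limit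
compound 3 `COc1ccc(-n2cc(COC(=O)/C(C)=C/CC/C(C)=C/CC/C(C)=C/CC[C@@H]3[C@@]4(C)CCC(=O)C(C)(C)[C@H]4CC[C@@]3(C)O)nn2)cc1`: 135000 nM

Of the three, compound 3 alone has a number, at 135000 nM. Compound 1 and compound 2 both rest on (the limit of > 150000 nM in this assay, at which 2 of the 3 values shown sit), which is a limit and not a number.

The next compound, compound 4 `C/C(=C\CC/C(C)=C/CC[C@@H]1[C@@]2(C)CCC(=O)C(C)(C)[C@H]2CC[C@@]1(C)O)CC/C=C(\C)C(=O)OCc1cn(-c2cccc(Cl)c2)nn1`, keeps everything else of compound 3 and changes one group: 3-chlorophenyl in place of 4-methoxyphenyl on an aromatic nitrogen. In words, this is 3-chlorophenyl in place of 4-methoxyphenyl on an aromatic nitrogen.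

Two measured steps at that place end in compound 3: an at least 1.1-fold lower number from compound 1 to compound 3 (0.04 log units; that floor lies within the scatter) and an at least 1.1-fold lower number from compound 2 to compound 3 (0.04 log units; that floor lies within the scatter). Both floors lie within the scatter, so neither gives a usable size. The third, a step that the two limits leave unreadable from compound 1 to compound 2, cannot be read at all. Compound 2, which carries 3-chloro-4-fluorophenyl, sits at the limit of > 150000 nM.

On this evidence, no step beyond the scatter is expected in this assay, in either direction, and a result reported only as a limit would be no surprise. The expected step, a 1.1-fold higher number from compound 3 to compound 4 (0.05 log units; within the scatter), is estimated to stay within the scatter. Compound 4 is estimated at 150000 nM, with an expected range of 90000 nM to 250000 nM.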

Compound 4, half-maximal inhibitory concentration: 103000 nM
Compound 4: the middle estimate sits 1.5-fold (0.16 log units) above what was measured; the range from low to high includes it.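

In this assay this position now has a step with a measured value at both ends, a 1.3-fold lower number from compound 3 to compound 4 (0.12 log units; within the scatter), so the exchange of 4-methoxyphenyl for 3-chlorophenyl can be read directly, and it does not separate the two groups. The steps that start from limits, an at least 1.4-fold lower number from compound 2 to compound 4 (0.16 log units; that floor lies within the scatter) and an at least 1.4-fold lower number from compound 1 to compound 4 (0.16 log units; that floor lies within the scatter), give only floors, so neither hydrogen in place of fluoro nor 3-chlorophenyl in place of 2-bromophenyl gets a usable size. Compound 1 and compound 2 remain limits and not numbers, and the step between them cannot be read: the limit of > 150000 nM in this assay, at which 2 of the 4 values shown sit.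

All the compounds shown carry a halogen-bearing or methoxy-bearing phenyl group on this aromatic nitrogen, and none of the readable steps goes beyond the scatter, so it remains open whether any group at this place can move the number that far. What an aminophenyl group, a carboxyphenyl group or a longer alkyl chain in place of the phenyl ring would do here is also left open, as is any change to the rest of the shared core.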